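This account rests on a few compounds, and the source may have more. Where it says the series, first, only, none or still open, it means among the compounds named here.

Among the measured compounds shown here, compound 2 `COc1ccc(Nc2cc(-c3ccc(C)cc3)ccn2)cc1` gives 34000 nM in an ADME assay on PBMC cells (Homo sapiens) for cytotoxicity, read by MTT assay, with a stated time of 72 h, in the presence of a further agent that is not named here (a higher number here means a weaker inhibitor, a lower number a stronger inhibitor), the lowest of the two numbers measured so far, while compound 1 `Cc1ccc(-c2ccnc(Nc3ccc(F)cc3)c2)cc1` gives 146000 nM in this assay. For the measured compounds named here, the only measured step, a 4.3-fold lower number from compound 1 to compound 2 (0.63 log units; beyond the scatter), changes a group on the other ring of the shared core. Going by the values given here, compound 3 `COc1ccc(Nc2ccccn2)cc1` differs from compound 2 as follows: hydrogen in place of 4-methylphenyl on an aromatic carbon This removes a group that both measured compounds share, and no measured step touches that group, so the step from compound 1 to compound 2 gives no direct guide to the size of this change. Without a measured removal of this group, the estimate rests on compound 2 alone and carries a wide range. A larger number, meaning a weaker effect, is expected: a 2.9-fold higher number from compound 2 to compound 3 (0.47 log units; beyond the scatter). Compound 3 is therefore expected to give about 100000 nM in this assay, within a range of 30000 nM to 300000 nM.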

Compound 3, half-maximal inhibitory concentration: 42000 nM
For compound 3 the middle estimate is 2.4-fold (0.38 log units) above the measured one; the measured number falls inside the stated range.
By their numbers in this assay, from the lowest: compounds 2 and 3 (each within the scatter of the next); then compound 1.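

On the aromatic carbon opposite the ring nitrogen, hydrogen in place of 4-methylphenyl gives a 1.2-fold higher number from compound 2 to compound 3 (0.09 log units; within the scatter) in this assay. Among the compounds shown here, this is the first measured step at this position, since the earlier step exchanged fluoro and methoxy elsewhere, and it shows that for this pair, the whole 4-methylphenyl group can go without the number leaving the usual scatter. Nothing available here explains why the two compounds read alike.

Going by these compounds, it remains open whether 4-methylphenyl could go just as freely with fluoro in place of methoxy, as in compound 1. On these data alone, it is also open whether a different group at this position, such as an amine or a carboxylic acid, would shift the number beyond the scatter.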